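This account rests on a few compounds, and the source may have more. Where it says the series, first, only, none or still open, it means among the compounds named here.

The three measured compounds share one core and differ only in the substitution of the outer aromatic ring. Compound 3 `Cc1ccccc1Cn1nc(C(=O)O)c2ccccc21` gives 186 mg/kg in a functional assay on the whole organism (Testis, strain Long-Evans) with Rattus norvegicus as the target, with a stated time of 5 days; on this read-out higher numbers stand for an effect only at larger amounts of compound and lower numbers for an effect already at smaller amounts. Compound 1 `O=C(O)c1nn(Cc2ccccc2Cl)c2ccccc12` gives 200 mg/kg in this assay, and the step of a 1.1-fold lower number from compound 1 to compound 3 (0.03 log units; within the scatter) falls within the scatter. Compound 2 `O=C(O)c1nn(Cc2ccc(Cl)c(Cl)c2)c2ccccc12` gives 448 mg/kg in this assay, a number that stands beyond the scatter from compound 3. Compound 4 `Cc1ccc(Cn2nc(C(=O)O)c3ccccc32)c(C)c1` carries methyl in place of hydrogen on an aromatic carbon. Among the compounds with values here, no measured step bears directly on this change, since the single measured step exchanges one group for another rather than adding one. What compound 1 and compound 2 show is that the doubly substituted ring gave the higher number. Compound 4 is therefore expected to give a somewhat higher number, a step of a 1.4-fold higher number from compound 3 to compound 4 (0.15 log units; within the scatter). The estimate for compound 4 is 260 mg/kg, between 120 mg/kg and 550 mg/kg.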

Compound 4, minimum effective dose: 101 mg/kg
Estimate against measurement, compound 4: 2.6-fold (0.41 log units) above; the whole stated range lies above it.
By their numbers in this assay, from the lowest: compounds 4, 3 and 1 (each within the scatter of the next); then compound 2.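

The step of a 1.8-fold lower number from compound 3 to compound 4 (0.27 log units; within the scatter) shows that, in this assay, this position para to a large group and meta to a methyl group takes a methyl in place of hydrogen without a change beyond the scatter. Within the data shown here, this is the first step that adds a group to the outer ring rather than exchanging one group for another. No measurement shown gives a reason for this result. As far as these compounds go, it remains open whether an amine, a methoxy group or a longer chain at this position would also stay within the scatter. From the compounds shown here alone, the effect of this methyl on a ring without the existing methyl group also remains open.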